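A few compounds are considered here, and "the series" means these few. Any claim that something is new, unique, unknown or untested is made for them only; others in the source may bear on it.

Measured so far in a functional assay on MCF7 cells (Homo sapiens) for cytotoxicity, read by MTT assay, with a stated time of 48 h; on this read-out lower numbers stand for stronger inhibition and higher numbers for weaker inhibition:
Compound 1 `COc1cc(C(=O)C2Sc3nnc(-c4cc(OC)c(OC)c(OC)c4)n3NC2c2ccco2)cc(OC)c1OC` gives > 100000 nM, which is a limit of the assay.
Compound 2 `COc1cc(-c2nnc3n2NC(c2ccco2)C(C(=O)c2ccccc2F)S3)cc(OC)c1OC` gives 94800 nM.
Compound 3 `COc1cc(-c2nnc3n2NC(c2ccco2)C(C(=O)c2ccc(F)cc2)S3)cc(OC)c1OC` gives > 100000 nM, which is a limit of the assay.

Compound 3 thus stands at the limit of > 100000 nM in this assay, at which 2 of the 3 values shown sit, so only a bound is known for it. The step that the two limits leave unreadable from compound 1 to compound 3 cannot be read at all. The steps of an at least 1.0-fold lower number from compound 1 to compound 2 (0.02 log units; that floor lies within the scatter) and an at least 1.0-fold higher number from compound 2 to compound 3 (0.02 log units; that floor lies within the scatter) are floors that lie inside the scatter, so across the three aryl groups so far placed on the carbonyl carbon no shift beyond scatter has appeared in this assay.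

Compound 4 `COc1cc(-c2nnc3n2NC(c2ccco2)C(C(=O)c2cccc4ccccc24)S3)cc(OC)c1OC` differs from compound 3 by naphthalen-1-yl in place of 4-fluorophenyl on a carbonyl carbon. Among the measured compounds shown here, no measured step covers this particular exchange; the measured steps bear on it only in that each earlier swap of the aryl group on the carbonyl carbon left the read-out at or near the top of the measured window, compound 2 giving 94800 nM. The expected step in this assay is therefore none beyond the scatter, a number no higher from compound 3 to compound 4 (the limit leaves the size open). Compound 4 is expected at 100000 nM, within 40000 nM to 250000 nM, most likely reported again only as a limit.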

Compound 4, half-maximal inhibitory concentration: > 100000 nM
Compound 4 ended at the assay's limit; the forecaster's own chance of this, stated with the estimate: 60%; the middle value sits exactly at the limit.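

In this assay compound 4 also stops at a limit of the assay, so a second six-membered aromatic ring on the carbonyl carbon, naphthalen-1-yl in place of 4-fluorophenyl, yields no measurable value: the limit of > 100000 nM in this assay, at which 3 of the 4 values shown sit. Against the only measured value in the series, the change gives an at least 1.0-fold higher number from compound 2 to compound 4 (0.02 log units; that floor lies within the scatter) and so shows no shift. The steps to compound 4 from compound 1 and from compound 3 cannot be read, as both ends of each are limits.

Going by these compounds, whether an aryl group carrying an amine or a carboxylic acid, or a plain alkyl chain, on the carbonyl carbon would bring the read-out into the measurable range remains open. Also open, on these data alone, is whether changes elsewhere on the shared core would do so.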